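Trifluoromethyl for methyl on the core of compound 1

A few compounds are considered here, and "the series" means these few. Any claim that something is new, unique, unknown or untested is made for them only; others in the source may bear on it.

In a functional assay on MCF7 cells (Homo sapiens) for antiproliferative activity, with a stated time of 96 h (a lower number here means a stronger inhibitor, a higher number a weaker inhibitor), compound 1 `Cc1cc(=O)oc2cc(OCC(=O)c3cc(C(F)(F)F)cc(C(F)(F)F)c3)ccc12` gives 470 nM, the lower of the two actual numbers in the series. Compound 2 `Cc1cc(=O)oc2cc(OCC(=O)c3cccc(C(F)(F)F)c3)ccc12` gives 38400 nM. The step between them is an 82-fold higher number from compound 1 to compound 2 (1.91 log units; beyond the scatter), with hydrogen in place of trifluoromethyl on an aromatic carbon. Compound 3 `Cc1cc(=O)oc2cc(OCC(=O)c3ccc(C(F)(F)F)cc3)ccc12` returns only a limit, > 100000 nM.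

Compound 4 `O=C(COc1ccc2c(C(F)(F)F)cc(=O)oc2c1)c1cc(C(F)(F)F)cc(C(F)(F)F)c1` differs from compound 1 by trifluoromethyl in place of methyl on an aromatic carbon, opposite the ring oxygen. Going by the values given here, no step at this place has been measured. Among the compounds with values here, the only measured step, an 82-fold higher number from compound 1 to compound 2 (1.91 log units; beyond the scatter), involves a different aromatic carbon, so it bears on the new change only indirectly. It shows that a single replacement can move this series far beyond the scatter, which argues for a wide range. Within the data shown here, with compound 1 at 470 nM as the best number so far, a moderately higher number is expected, though the direction is uncertain. The expected change is a 2.6-fold higher number from compound 1 to compound 4 (0.41 log units; beyond the scatter). For compound 4 the estimated value is 1200 nM, with an expected range of 200 nM to 8000 nM.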

Compound 4, half-maximal inhibitory concentration: "not active" (no number reported)
Compound 4: no number reported; there is nothing to compare the estimate with.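

Going by these compounds alone, compound 4 is reported as "not active" in this assay, without a number, so no step from compound 1 to compound 4 can be read. It remains open how far trifluoromethyl in place of methyl moves the number, and whether compound 4 lies near the limit of compound 3: the limit of > 100000 nM in this assay, at which 1 of the 4 values shown sits.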